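Methoxy added to the phenyl of compound 1

The source may report more compounds than this note shows. Statements on the series, on what has been measured and on what is new or still open speak of the compounds shown alone.

Compound 1 `COc1ccc(-c2nc(SCC(=O)c3sc(-c4ccccc4)nc3C)[nH]c(=O)c2C#N)cc1` carries the core shared by this small set. In a functional assay on U-87MG ATCC cells for antiproliferative activity against U-87 MG (Homo sapiens), read by MTT assay, with a stated time of 48 h, tested at 100 uM (a lower number here means a stronger effect, a higher number a weaker effect of the compound at the concentration tested), compound 1 gives 1.08%, the lowest of the three numbers recorded. Compound 2 `Cc1nc(-c2ccc(Cl)cc2)sc1C(=O)CSc1nc(N)c(C#N)c(-c2ccc(Cl)cc2)n1` gives 1.65% in this assay, a figure within the scatter of compound 1, so the two cannot be ordered. Compound 3 `COc1ccc(-c2nc(SCC(=O)c3sc(-c4ccccc4)nc3C)nc(N)c2C#N)cc1` gives 17.2%, which sits beyond the scatter above compound 1. For the measured compounds named here, no step between measured compounds that differ in one place is available, so the effect of a single change at the position in question is not known from these data.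

Compound 4 `COc1ccc(-c2nc(C)c(C(=O)CSc3nc(-c4ccc(OC)cc4)c(C#N)c(=O)[nH]3)s2)cc1` differs from compound 1 by methoxy in place of hydrogen on an aromatic carbon. Since compound 1 already gives 1.08%, a small number, a step of a number 1.9 percentage points higher from compound 1 to compound 4 (within the scatter) is expected, in no direction beyond the scatter. The read-out of compound 4 is therefore estimated at 3%, with a range from 0.5% to 15%.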

Compound 4, a percentage reported as activity, at one concentration (the size of the read-out at that concentration, not a potency): 11.5%
Beside the measured number, compound 4's estimate is 8.5 percentage points below it, and the stated range covers the measured number.
By their numbers in this assay, from the lowest: compounds 1, 2, 4 and 3 (each within the scatter of the next, the first and the last beyond it).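

In this assay, for the compounds shown here, phenyl to 4-methoxyphenyl is the only single-place change available so far, and it gives a number 10.4 percentage points higher from compound 1 to compound 4 (beyond the scatter). This position therefore responds to substitution: methoxy in place of hydrogen weakens the effect at the concentration tested, though the step is modest and compound 4 still gives 11.5%. The data on hand offer no explanation for this step.

Open, going by these compounds, is how other groups at this position compare, for example fluorine, hydroxyl, an amine or a longer ether chain such as ethoxy. Also open, on these data alone, is whether the same change from phenyl to 4-methoxyphenyl gives a similar step on the core of compound 3, which carries an amine where compound 1 carries a carbonyl and the ring hydrogen.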